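The source may hold more compounds than are shown below. What is called first, only, known or untested is meant among the compounds shown, and "the series" means these compounds.

Measured so far in an assay on brain for binding affinity to Neuronal acetylcholine receptor; alpha4/beta2 (Homo sapiens); on this read-out higher numbers stand for weaker inhibition and lower numbers for stronger inhibition:
compound 1 `CN(C)CCC#Cc1cccnc1`: 510 nM.
compound 2 `CNCCC#Cc1ccc(OC)nc1`: > 10000 nM, a limit of the assay and not a number.

For the measured compounds named here, compound 1 holds the only definite number in this assay; the one other value recorded is a limit (the limit of > 10000 nM in this assay, at which 1 of the 2 values shown sits). Compound 2 reaches only that limit. Going by the values given here, compound 1 and compound 2 differ in more than one place, so no single step connects them, and their two values show only that one compound gives a number and the other gives a limit.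

Compound 3 `C[N+](C)(C)CCC#Cc1cccnc1` is not yet measured. It differs from compound 1 by a group of 4 heavy atoms (3 carbon, 1 nitrogen; no ring) in place of a group of 3 heavy atoms (2 carbon, 1 nitrogen; no ring), on a saturated chain carbon, two bonds along the chain from a triple-bonded carbon. No measured step of this kind exists in the series, so the expectation rests on compound 1 alone, with no measured cause to point to. The change is expected to be modest in this assay, a 1.3-fold lower number from compound 1 to compound 3 (0.11 log units; within the scatter), either within the scatter or only somewhat beyond it, in either direction. Compound 3 is accordingly estimated at 400 nM in this assay, with a range from 80 nM to 2000 nM.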

Compound 3, inhibition constant: 470 nM
For compound 3 the middle estimate is 1.2-fold (0.07 log units) below the measured one; the range from low to high includes it.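

In this assay, the series now has its first change in a single place, on a saturated chain carbon, two bonds along the chain from a triple-bonded carbon, and it reads a 1.1-fold lower number from compound 1 to compound 3 (0.04 log units; within the scatter). The dimethylamino group of compound 1, with no net charge and 1 hydrogen-bond acceptor, can therefore be replaced here by a group with net charge +1 and 0 hydrogen-bond acceptors, and the two compounds stay within the scatter of each other; on this core, neither the absence of a net charge nor that acceptor is needed for a value of this size. Nothing recorded for the series bears on a cause for this step.

Still open, going by these compounds, is whether other groups at this place, such as a primary amine or a pyrrolidine, or a longer chain, would keep a value of this size. For the compounds shown here, compound 2 gives > 10000 nM, a limit and not a number, and no single step connects it to the other compounds, so what sets it apart cannot be read.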